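Swapping One Amide Group on Compound 2

The source may report more compounds than this note shows. Statements on the series, on what has been measured and on what is new or still open speak of the compounds shown alone.

Within the data shown here, in a functional assay on PC-3 cells (Homo sapiens) for inhibition, read by sulforhodamine B assay, with a stated time of 72 h (on this read-out lower numbers stand for stronger inhibition and higher numbers for weaker inhibition), compound 2 `Nc1sc(-c2ccc(Cl)cc2)c(-c2ccc(Cl)cc2)c1C(=O)NC1CCC(O)CC1` gives 5670 nM and so holds the lower of the two numbers measured so far, while compound 1 `CCOC(=O)Nc1sc(-c2ccc(Cl)cc2)c(-c2ccc(Cl)cc2)c1C(=O)NC1CC1` gives 27600 nM as the higher one. Compound 3 `COc1ccc(CNC(=O)c2c(N)sc(-c3ccc(Cl)cc3)c2-c2ccc(Cl)cc2)cc1` keeps the shared core of compound 2 but carries 4-methoxybenzyl in place of 4-hydroxycyclohexyl on an amide-type nitrogen. Among the measured compounds shown here, no measured pair shows this kind of swap on its own, so the expected change in this assay is small and stays within the scatter (a 1.1-fold higher number from compound 2 to compound 3 (0.06 log units; within the scatter)). The estimate for compound 3 is 6500 nM with an expected range from 2300 nM to 20000 nM for the measurement still to come.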

Compound 3, half-maximal inhibitory concentration: 29500 nM
Compound 3: middle estimate off by 4.5-fold (0.66 log units), on the low side; measured number outside the range, above it.
By their numbers in this assay, from the lowest: compound 2; then compounds 1 and 3 (each within the scatter of the next).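

Among these compounds, this is the first step that changes only the group on this amide-type nitrogen: in this assay, 4-methoxybenzyl in place of 4-hydroxycyclohexyl gives a 5.2-fold higher number from compound 2 to compound 3 (0.72 log units; beyond the scatter). With the shared core unchanged, the number therefore responds to this group. The two groups differ in both ring type and hydrogen-bond donors, and nothing available explains the weaker inhibition. The compounds shown leave open how a plain cyclohexyl or a 4-hydroxybenzyl group would read on this nitrogen. Such groups could help separate the ring change from the change in the oxygen-bearing substituent.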